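Notes on the fluorinated aryl series, compounds 1 to 4

This account rests on a few compounds, and the source may have more. Where it says the series, first, only, none or still open, it means among the compounds named here.

Values are half-maximal inhibitory concentrations in a functional assay on HeLa cells (Homo sapiens) for inhibition; a higher number here means a weaker inhibitor, a lower number a stronger inhibitor.

compound 1, `Oc1ccccc1-c1cc(-c2ccccc2F)cc(-c2ccccc2O)n1`: > 50000 nM
compound 2, `Oc1ccccc1-c1cc(-c2cccc(F)c2)cc(-c2ccccc2O)n1`: > 50000 nM
compound 3, `Oc1ccccc1-c1cc(-c2cccc(C(F)(F)F)c2)cc(-c2ccccc2O)n1`: > 50000 nM

Compound 3 stands at the limit of this assay, > 50000 nM, and this is a limit, not a number. Compound 1 also reports only a limit, > 50000 nM. Compound 2 likewise reports only a limit, > 50000 nM. The three measured steps, a step that the two limits leave unreadable from compound 1 to compound 2, a step that the two limits leave unreadable from compound 1 to compound 3 and a step that the two limits leave unreadable from compound 2 to compound 3, have no readable size because all three values sit at the limit of > 50000 nM in this assay, at which 3 of the 3 values shown sit.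

Compound 4, `Oc1ccccc1-c1cc(-c2ccc(C(F)(F)F)cc2)cc(-c2ccccc2O)n1`, is not yet measured in this assay. It differs from compound 3 by 4-(trifluoromethyl)phenyl in place of 3-(trifluoromethyl)phenyl on an aromatic carbon. Among the measured compounds shown here, no measured step bears on this move with a readable size, and every value so far is a limit. No step beyond the scatter is therefore expected, and the likely outcome is again a limit. The expected step is a step that the limit leaves unreadable from compound 3 to compound 4. Compound 4 is estimated at 90000 nM, with a range from 30000 nM to 400000 nM.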

Compound 4, half-maximal inhibitory concentration: > 50000 nM
Compound 4 gave a limit, no number (the forecaster's own chance of this, stated with the estimate: 85%); the middle value does not contradict the limit.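

In this assay compound 4 gives > 50000 nM, which is a limit and not a number. Among the compounds shown here, no step among compound 1, compound 2, compound 3 and compound 4 can be read, because all four values stand at the same limit: (the limit of > 50000 nM in this assay, at which 4 of the 4 values shown sit). The compounds shown leave open whether any aryl group at this place on the shared core gives a readable value in this assay.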